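This account rests on a few compounds, and the source may have more. Where it says the series, first, only, none or still open, it means among the compounds named here.

Working notes on the series. In a functional assay on MCF7 cells (Homo sapiens) for cytotoxicity, read by WST assay, with a stated time of 72 h (a lower number here means a stronger inhibitor, a higher number a weaker inhibitor), compound 1 (`COc1ccc(C2(c3ccc(O)cc3)C(=O)Nc3c2ccc(F)c3F)cc1`) gives 2.1 nM; 6.3 nM; > 1000 nM (3 entries). The entry of compound 1 that carries a sign is a limit of the assay and not a number. Compound 2 (`O=C1Nc2c(ccc(F)c2F)C1(c1ccc(O)cc1)C1CCCC1`) stands at 12 nM. Compound 3 (`O=C1Nc2c(ccc(F)c2F)C1(c1ccc(O)cc1)C1CCCCCC1`) stands at 1.2 nM, the lower of the two single numbers in the series, with compound 2 as its nearest neighbour.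

Compound 4 (`O=C1Nc2c(ccc(F)c2F)C1(c1ccc(O)cc1)C1CCCCCCC1`) is not yet measured. It differs from compound 3 in one place, on a saturated ring carbon of a five-membered non-aromatic ring with 1 nitrogen, with cyclooctyl in place of cycloheptyl on a saturated ring carbon.

Going by the values given here, one measured step bears on this change: a 10-fold lower number from compound 2 to compound 3 (1.00 log units; beyond the scatter), with cycloheptyl in place of cyclopentyl on that same carbon. The larger ring gave the lower number there, but a single step sets no trend, and a further fall cannot be assumed. No step beyond the scatter is therefore expected in this assay, and no firm direction is expected either. The expected change is a 1.2-fold lower number from compound 3 to compound 4 (0.08 log units; within the scatter). For compound 4 the estimated value is 1 nM, with an expected range of 0.25 nM to 5 nM.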

Compound 4, half-maximal inhibitory concentration: > 1000 nM
Compound 4: no number, only a limit; the forecaster's own chance of this, stated with the estimate: 5%; middle value at least 1000-fold (3.00 log units) from the limit.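

In this assay the value of compound 4 is a limit of the assay and not a number, so the change from cycloheptyl to cyclooctyl on this saturated ring carbon can be read only as a bound: an at least 830-fold higher number from compound 3 to compound 4 (2.92 log units; beyond the scatter). Ring size at this position therefore does not act in one direction across the three compounds: cycloheptyl in place of cyclopentyl gave a 10-fold lower number from compound 2 to compound 3 (1.00 log units; beyond the scatter), whereas cyclooctyl in place of cyclopentyl gives an at least 83-fold higher number from compound 2 to compound 4 (1.92 log units; beyond the scatter), so compound 4 goes against any trend of lower numbers with larger rings. The reading rests on a single entry for compound 4, and its firmness is uncertain given the spread in the only compound shown with repeated entries: the several entries of compound 1 in this assay, 2.1 nM; 6.3 nM; > 1000 nM (3 entries)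

The compounds shown leave open how the numbers run through cyclohexyl, which would fill the gap between cyclopentyl and cycloheptyl. They also leave open whether the sharp change belongs to ring size alone, which an open chain such as n-heptyl or a cycloheptyl ring carrying an amine could help to separate.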